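The compounds below may be only part of what the source reports. "The series", "measured", "known", "first", "only" and "open" are said of these compounds alone.

Measured in an ADME assay on Huh-7 cells (Homo sapiens) for cytotoxicity, with a stated time of 72 h; on this read-out higher numbers stand for lower toxicity in this test and lower numbers for higher toxicity in this test:
- compound 1 `COc1ccc(/C=C\c2cc(OC)c(OC)c(OC)c2)cc1NC(=O)[C@H](CO)NC(=O)[C@H](CCCNC(=N)N)NC(=O)[C@H](CCCCN)NC(=O)c1ccccc1`: 134 nM
- compound 2 `COc1ccc(/C=C\c2cc(OC)c(OC)c(OC)c2)cc1NC(=O)CNC(=O)[C@H](CCCNC(=N)N)NC(=O)[C@H](CCCNC(=N)N)NC(=O)c1ccccc1`: 26.6 nM

Of these two, compound 2 has the lower number at 26.6 nM, and its gap to compound 1 lies beyond the scatter. Compound 3 `COc1ccc(/C=C\c2cc(OC)c(OC)c(OC)c2)cc1NC(=O)CNC(=O)[C@H](CCCNC(=N)N)NC(=O)[C@H](CCCCN)NC(=O)c1ccccc1` departs from compound 2 in one place: a group of 2 heavy atoms (1 carbon, 1 nitrogen; no ring) in place of a group of 4 heavy atoms (1 carbon, 3 nitrogen; no ring), on a saturated chain carbon, four bonds along the chain from an amide-type nitrogen and a carbonyl carbon. The aminomethyl stands on a saturated chain carbon, four bonds along the chain from an amide-type nitrogen and a carbonyl carbon. Within the data shown here, no measured pair isolates this change, so its size remains unknown. A rise in this assay is expected, near the edge of the scatter, with compound 2 at 26.6 nM as the lower reference and compound 1 at 134 nM as the upper one. The expected change is a 2.3-fold higher number from compound 2 to compound 3 (0.35 log units; beyond the scatter). For compound 3 the estimated value is 60 nM, with an expected range of 25 nM to 140 nM.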

Compound 3, half-maximal cytotoxic concentration: 172 nM
Compound 3: middle estimate off by 2.9-fold (0.46 log units), on the low side; the measured number lies above the stated range.
By their numbers in this assay, from the lowest: compound 2; then compounds 1 and 3 (each within the scatter of the next).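

In this assay, the position four bonds along the chain from an amide-type nitrogen and a carbonyl carbon now has a readable step: aminomethyl in place of the group of 4 heavy atoms (1 carbon, 3 nitrogen) gives (a 6.5-fold higher number from compound 2 to compound 3 (0.81 log units; beyond the scatter)), so the read-out responds to this change. At the saturated chain carbon bound to an amide-type nitrogen and a carbonyl carbon, hydrogen in place of hydroxymethyl gives (a 1.3-fold higher number from compound 1 to compound 3 (0.11 log units; within the scatter)), and this step stays within the scatter, so no effect of that swap can be read. No measurement at hand accounts for the step at the aminomethyl position.

Still open, as far as these compounds go, is whether a longer chain ending in an amine, or a carboxylic acid, at this position would follow compound 3 or compound 2. Also open, from the compounds shown here alone, is whether the aminomethyl step holds size when hydroxymethyl is present on the other chain carbon.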